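The source may report more compounds than this note shows. Statements on the series, on what has been measured and on what is new or still open speak of the compounds shown alone.

In a physicochemical assay for solubility, in phosphate buffer, measured as kinetic solubility (on this read-out lower numbers stand for lower solubility and higher numbers for higher solubility), compound 1 (`CCc1nn2c(-c3c(COC)cc(OC)cc3OC)cccc2c1N(CC1CCOCC1)CC1CC1`) gives 2900 nM, while compound 2 (`COCc1cc(OC)c(-c2cccc3c(N(CC4CCOCC4)CC4CC4)c(C)nn23)c(OC)c1`) gives 21000 nM. Compound 2 therefore holds the higher of the two numbers, and the gap between them lies beyond the usual scatter of repeat measurements. The next compound to consider is compound 3 (`CCc1nn2c(-c3c(OC)cc(COC)cc3OC)cccc2c1N(CC1CCOCC1)CC1CC1`). Its difference from compound 2 is methyl in place of hydrogen on a saturated chain carbon bound to an aromatic carbon, with methyl in place of hydrogen on a saturated chain carbon bound to an aromatic carbon, a change that also reads as methyl to ethyl. Going by the values given here, no measured pair shows this change alone, so the expectation rests on two reference values: compound 2 at 21000 nM as the starting point and compound 1 at 2900 nM as a lower guide. A moderate fall in this assay, slightly beyond the scatter, is the expected size and direction of the step of a 2.6-fold lower number from compound 2 to compound 3 (0.42 log units; beyond the scatter). Compound 3 is estimated to give about 8000 nM, within an expected range of 2800 nM to 20000 nM.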

Compound 3, solubility: 4800 nM
Compound 3: the middle estimate sits 1.7-fold (0.22 log units) above what was measured, within the range that was stated.
By their numbers in this assay, from the lowest: compounds 1 and 3 (each within the scatter of the next); then compound 2.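

In this assay, a methyl in place of hydrogen on a saturated chain carbon bound to an aromatic carbon, which also reads as methyl to ethyl, gives a 4.4-fold lower number from compound 2 to compound 3 (0.64 log units; beyond the scatter), while the rest of the structure stays the same. Going by these compounds alone, this is the first measured pair in which this change stands alone, so its size can now be read directly, and it lies beyond the usual scatter although the entering group adds only one carbon, with no ring, no hydrogen-bond donor or acceptor and no net charge. No measurement shown here offers an explanation for the step.

The compounds shown leave open how a longer chain such as propyl, or an amine on the same carbon, would compare. This single pair also cannot show whether the same change would give a similar step on a different compound.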